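This account rests on a few compounds, and the source may have more. Where it says the series, first, only, none or still open, it means among the compounds named here.

Compound 1 `Cc1cc(NNC(=O)Nc2cc(Cl)nc(Cl)c2)ncc1C#N`: 7 nM
Compound 2 `CCOc1cc(NC(=O)NCc2cc(C)c(-c3cn(C)nc3C)cn2)cc(Cl)n1`: 0.32 nM
Compound 3 `Cc1cc(CNC(=O)Nc2cc(OCC(O)CO)nc(C(F)(F)F)c2)nnc1-c1cn(C)nc1C(F)(F)F`: > 11000 nM

All three were tested in a functional assay on CHO cells for antagonist activity at sphingosine 1-phosphate receptor 2 (Homo sapiens), read by scintillation counting and GTPgammaS binding, with a stated time of 4 h, in the presence of a further agent that is not named here; on this read-out lower numbers stand for stronger inhibition and higher numbers for weaker inhibition. Compound 1 gives 7 nM and compound 2 gives 0.32 nM. Compound 3 stands apart from both. Its result is not a number but a limit of the assay, > 11000 nM. Among the three results, compound 3 alone sits at the limit of > 11000 nM in this assay, at which 1 of the 3 values shown sits.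

Compound 4 `Cc1cc(CNC(=O)Nc2cc(OCCO)nc(C(F)(F)F)c2)nnc1-c1cn(C)nc1C(F)(F)F` has not yet been measured. It differs from compound 3 in one place: hydrogen in place of hydroxymethyl on a saturated chain carbon bound to an oxygen on a saturated carbon and a saturated chain carbon. Within the data shown here, no two measured compounds differ in a single place, so no measured step shows what this kind of change does in this assay. With compound 3 known only as a limit, the starting point itself is uncertain. The step from compound 3 to compound 4 is expected to be an at least 1.2-fold lower number from compound 3 to compound 4 (0.08 log units; that floor lies within the scatter), small and within the usual scatter, with a fair chance that compound 4 also reports only a limit. Compound 4 is therefore expected to give about 9000 nM, with a range from 1500 nM to 25000 nM.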

Compound 4, half-maximal inhibitory concentration: 704 nM
Estimate against measurement, compound 4: 13-fold (1.11 log units) above, and the stated range ends above it.
By their numbers in this assay, from the lowest: compound 2; then compound 1; then compound 4. At a limit, above all of these: compound 3.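

The earlier compounds shown here included no pair differing in one place, so they showed nothing about this part of the side chain in this assay. Shortening 2,3-dihydroxypropoxy to 2-hydroxyethoxy, with hydrogen in place of hydroxymethyl, gives an at least 15-fold lower number from compound 3 to compound 4 (1.19 log units; beyond the scatter), which shows that this small change at this position can move the result from a limit of the assay to a measured number. Compound 3 gives > 11000 nM, which is a limit and not a number, and the full size of the step therefore stays unknown: the limit of > 11000 nM in this assay, at which 1 of the 4 values shown sits.

As far as these compounds go, whether a 2-methoxyethoxy or a 2-aminoethoxy group in the same place would lower or raise the number remains open. Also open, from the compounds shown here alone, is whether the hydroxyl of the 2-hydroxyethoxy group is needed at all, or whether the length of the chain alone sets the result.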